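From Compound 2 to Compound 3: A Sulfonamide Swap

This account rests on a few compounds, and the source may have more. Where it says the series, first, only, none or still open, it means among the compounds named here.

In a functional assay on MCF7 cells (Homo sapiens) for antiproliferative activity, read by MTT assay, with a stated time of 72 h (on this read-out lower numbers stand for stronger inhibition and higher numbers for weaker inhibition), compound 1 `Cc1cccc(N(C)S(=O)(=O)C2CC3OC2C(c2ccc(NC(=O)CCCCCCC(=O)O)cc2)=C3c2ccc(O)cc2)c1` gives 30200 nM while compound 2 `CN(c1cccc2ccccc12)S(=O)(=O)C1CC2OC1C(c1ccc(NC(=O)CCCCCCC(=O)O)cc1)=C2c1ccc(O)cc1` gives 14000 nM as the lower of the two numbers. Among the compounds with values here, the only measured step is a 2.2-fold lower number from compound 1 to compound 2 (0.33 log units; beyond the scatter) with naphthalen-1-yl in place of 3-methylphenyl on a sulfonamide nitrogen. Compound 3 `CCN(c1ccccc1)S(=O)(=O)C1CC2OC1C(c1ccc(NC(=O)CCCCCCC(=O)O)cc1)=C2c1ccc(O)cc1` differs from compound 2 by ethyl(phenyl)amino in place of methyl(naphthalen-1-yl)amino on a sulfonyl sulfur in a single swap: ethyl(phenyl)amino in place of methyl(naphthalen-1-yl)amino on a sulfonyl sulfur. Within the data shown here, compound 3 loses the naphthalen-1-yl group, so the closest guide is compound 1 at 30200 nM and a modest move toward a higher number is expected in this assay with a size like that of the one measured step. Among the measured compounds shown here, no measured compound carries the ethyl group, so the range stays wide. The expected step is a 1.9-fold higher number from compound 2 to compound 3 (0.27 log units; within the scatter) as an estimate only. For compound 3 the estimated value is 26000 nM with a likely range from 12000 nM to 55000 nM in this estimate.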

Compound 3, half-maximal inhibitory concentration: 19100 nM
For compound 3 the middle estimate is 1.4-fold (0.13 log units) above the measured one, and the stated range covers the measured number.
By their numbers in this assay, from the lowest: compounds 2, 3 and 1 (each within the scatter of the next, the first and the last beyond it).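

In this assay, methyl(naphthalen-1-yl)amino with 12 heavy atoms gives way on the sulfonyl sulfur to ethyl(phenyl)amino with 9, and the outcome is a 1.4-fold higher number from compound 2 to compound 3 (0.13 log units; within the scatter) so a smaller group with one aromatic ring instead of two leaves the number within the usual spread of repeats. The comparison with the methyl(3-methylphenyl)amino group gives a 1.6-fold lower number from compound 1 to compound 3 (0.20 log units; within the scatter) and so the new number cannot be told apart from either of the other two, although those two differ from each other beyond the scatter. Nothing available explains these numbers.

In this swap the ethyl group and the loss of a ring come together, so methyl(phenyl)amino would be needed to separate them. As far as these compounds go, whether this position needs an aromatic ring at all stays open, and a cyclohexyl group on the sulfonamide nitrogen would test that.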